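Aryl exchange on the shared core: compound 2 to compound 3

A few compounds are considered here, and "the series" means these few. Any claim that something is new, unique, unknown or untested is made for them only; others in the source may bear on it.

In a functional assay on A549 cells (Homo sapiens) for antiproliferative activity, read by MTT assay, with a stated time of 72 h (on this read-out lower numbers stand for stronger inhibition and higher numbers for weaker inhibition), compound 1 (`COc1ccccc1-c1ccc2ncn(-c3cc(OC)c(OC)c(OC)c3)c2c1`) gives 4320 nM and compound 2 (`COc1cc(-n2cnc3ccc(-c4ccc(C(F)(F)F)cc4)cc32)cc(OC)c1OC`) gives 3390 nM so the two lie within the scatter of each other. Going by the values given here, the only measured step is a 1.3-fold lower number from compound 1 to compound 2 (0.11 log units; within the scatter) with 4-(trifluoromethyl)phenyl in place of 2-methoxyphenyl on an aromatic carbon. Compound 3 (`COc1cc(-n2cnc3ccc(-c4cccc(N)c4)cc32)cc(OC)c1OC`) brings 3-aminophenyl in place of 4-(trifluoromethyl)phenyl on an aromatic carbon with 3-aminophenyl in place of 4-(trifluoromethyl)phenyl on an aromatic carbon. Among the compounds with values here, no measured compound carries an amino group, so that single step is a thin guide. The expected change is a 1.1-fold lower number from compound 2 to compound 3 (0.05 log units; within the scatter) in this assay and no shift beyond the scatter is foreseen. Compound 3 is estimated at 3000 nM with an expected range from 800 nM to 10000 nM for repeat measurements.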

Compound 3, half-maximal inhibitory concentration: 640 nM
For compound 3 the middle estimate is 4.7-fold (0.67 log units) above the measured one; the measured number lies below the stated range.
By their numbers in this assay, from the lowest: compound 3; then compounds 2 and 1 (each within the scatter of the next).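

In this assay the change to 3-aminophenyl gives a 5.3-fold lower number from compound 2 to compound 3 (0.72 log units; beyond the scatter) and a 6.8-fold lower number from compound 1 to compound 3 (0.83 log units; beyond the scatter) so this aromatic carbon of the shared core does respond to the choice of aryl group. Going by these compounds alone, the 4-(trifluoromethyl)phenyl and 2-methoxyphenyl groups had not separated beyond the scatter, and 3-aminophenyl is the first group here to do so, though the step remains modest. Open, going by these compounds, is whether the amino group itself carries the step, and how a hydroxyl or an acetamide on the same phenyl ring would read. Nothing available explains the step.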